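Aryl ketone variation on a trimethoxyphenyl pyrazole chalcone scaffold

The source may report more compounds than this note shows. Statements on the series, on what has been measured and on what is new or still open speak of the compounds shown alone.

Measured in a functional assay on MCF7 cells (Homo sapiens) for cytotoxicity, read by sulforhodamine B assay, with a stated time of 48 h, tested at 1 uM; a lower number here means a stronger effect, a higher number a weaker effect of the compound at the concentration tested:
compound 1 `COc1cc(-c2cc(/C=C/C(=O)c3ccc(Cl)c(Cl)c3)[nH]n2)cc(OC)c1OC` gives 62%
compound 2 `COc1ccc(C(=O)/C=C/c2cc(-c3cc(OC)c(OC)c(OC)c3)n[nH]2)cc1OC` gives 31%
compound 3 `COc1ccc(C(=O)/C=C/c2cc(-c3cc(OC)c(OC)c(OC)c3)n[nH]2)cc1` gives 57%

Compound 3 stands second highest of the three numbers. Its nearest neighbour is compound 1, with a number 5 percentage points lower from compound 1 to compound 3 (within the scatter); its furthest is compound 2, with a number 26 percentage points higher from compound 2 to compound 3 (beyond the scatter). Compound 4 `COc1cc(-c2cc(/C=C/C(=O)c3ccc(F)c(F)c3)[nH]n2)cc(OC)c1OC` differs from compound 3 in one place: 3,4-difluorophenyl in place of 4-methoxyphenyl on a carbonyl carbon. The step that bears most directly on this change is a number 5 percentage points lower from compound 1 to compound 3 (within the scatter), where a dihalogenated ring on the carbonyl carbon gave a number that did not separate from the 4-methoxyphenyl analogue. Among the measured compounds shown here, no step covers fluorine on that ring. The expected step is therefore a number 1 percentage points higher from compound 3 to compound 4 (within the scatter), within the scatter. Compound 4 is estimated at 58%, range 42% to 74%.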

Compound 4, a percentage reported as activity, at one concentration (the size of the read-out at that concentration, not a potency): 99%
Compound 4: middle estimate off by 41 percentage points, on the low side; measured number above the stated range.
By their numbers in this assay, from the lowest: compound 2; then compounds 3 and 1 (each within the scatter of the next); then compound 4.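

In this assay the 3,4-difluorophenyl group on the carbonyl carbon separates from all three other aryl groups, with a number 42 percentage points higher from compound 3 to compound 4 (beyond the scatter) and a number 37 percentage points higher from compound 1 to compound 4 (beyond the scatter) and a number 68 percentage points higher from compound 2 to compound 4 (beyond the scatter) as the steps, leaving compound 4 the weakest of the four at this concentration. The two dihalogenated rings therefore do not read alike at this position, and the match between 3,4-dichlorophenyl and 4-methoxyphenyl does not extend to 3,4-difluorophenyl. Nothing available accounts for this difference.

Open, going by these compounds, is how a 4-fluorophenyl group would read at this position, and whether it would sit with compound 4 or compound 1. Also open, on these data alone, is how an amine or a carboxylic acid on that ring would compare with the methoxy groups of compound 2.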